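A few compounds are considered here, and "the series" means these few. Any claim that something is new, unique, unknown or untested is made for them only; others in the source may bear on it.

In a functional assay (aorta) for antagonist activity, with Oryctolagus cuniculus as the target (a lower number here means a stronger inhibitor, a higher number a weaker inhibitor), compound 1 (`CCCSC1=Nc2ccccc2S(=O)(=O)N1Cc1ccc(-c2ccccc2C(=O)O)cc1`) gives 1200 nM, while compound 2 (`CCSC1=NS(=O)(=O)c2cc(C)cnc2N1Cc1ccc(-c2ccccc2-c2nn[nH]n2)cc1`) gives 0.6 nM, the lower of the two numbers and beyond the scatter. Compound 3 (`CCCSC1=NS(=O)(=O)c2cc(C)cnc2N1Cc1ccc(-c2ccccc2-c2nn[nH]n2)cc1`) differs from compound 2 by methyl in place of hydrogen on a saturated chain carbon, two bonds along the chain from a sulfur, which turns ethylsulfanyl into propylsulfanyl. Going by the values given here, no measured pair shows this change alone, so the expectation is only that such a small addition leaves this assay close to where compound 2 stands, with no step beyond the scatter. The expected step, a 1.3-fold higher number from compound 2 to compound 3 (0.12 log units; within the scatter), is therefore small. For compound 3 the estimated value is 0.8 nM, within a range of 0.25 nM to 2.5 nM.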

Compound 3, antagonist equilibrium constant: 11 nM
Estimate against measurement, compound 3: 14-fold (1.14 log units) below, outside the stated range (above it).
By their numbers in this assay, from the lowest: compound 2; then compound 3; then compound 1.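

In this assay the change from ethylsulfanyl to propylsulfanyl gives an 18-fold higher number from compound 2 to compound 3 (1.26 log units; beyond the scatter) and so shows that a single methyl, on a saturated chain carbon, two bonds along the chain from a sulfur, is enough to weaken inhibition markedly. Going by these compounds alone, compound 1 also carries propylsulfanyl, but it differs from compound 3 in more than one place, so only this pair isolates the chain. Nothing available here accounts for the size of this step. Open remains whether a butyl chain would weaken inhibition further, and how methylsulfanyl or an amine at the sulfur's place would stand.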